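The source may report more compounds than this note shows. Statements on the series, on what has been measured and on what is new or still open speak of the compounds shown alone.

Measured so far in a toxicity assay (L6 cells) for cytotoxicity, with Rattus norvegicus as the target, read by resazurin assay, with a stated time of 70 h (a higher number here means a weaker inhibitor, a lower number a stronger inhibitor), are these compounds:

compound 1 `N=C(N)c1ccc2nc(-c3ccc(C(=N)N)o3)[nH]c2c1` gives 151000 nM
compound 2 `c1cc2nc(-c3ccc(C4=NCCN4)s3)[nH]c2cc1C1=NCCN1` gives 129000 nM
compound 3 `Cn1c(-c2ccc(C(=N)N)cc2)nc2cc(C(=N)N)ccc21` gives > 169000 nM

Compound 3 stands at a limit of the assay, > 169000 nM as reported, and not at a number. Compound 4 `CCn1c(-c2ccc(C(=N)N)cc2)nc2cc(C(=N)N)ccc21` alters compound 3 in one place, counted as methyl in place of hydrogen on a saturated chain carbon bound to an aromatic nitrogen in all: methyl in place of hydrogen on a saturated chain carbon bound to an aromatic nitrogen, so methyl becomes ethyl. Within the data shown here, no measured pair shows this change in this assay so no step beyond the usual scatter is expected. Among the measured compounds shown here, compound 1 at 151000 nM and compound 2 at 129000 nM lie within scatter of each other and are the only true numbers available. What is expected is an at least 1.2-fold lower number from compound 3 to compound 4 (0.08 log units; that floor lies within the scatter) and nothing larger. The estimate for compound 4 is 140000 nM with an expected range from 60000 nM to 250000 nM as its span.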

Compound 4, half-maximal inhibitory concentration: > 207000 nM
Compound 4 was reported as a limit (the forecaster's own chance of this, stated with the estimate: 50%); middle value at least 1.4-fold (0.16 log units) from the limit.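

Among these compounds, compound 3 and compound 4 both stand at limits of this assay, not at true numbers, and no step between them can be read. From the compounds shown here alone, whether changing methyl to ethyl shifts the reading at all remains open.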